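An Aryl Swap on an Amide-Type Nitrogen

The compounds below may be only part of what the source reports. "The series", "measured", "known", "first", "only" and "open" are said of these compounds alone.

In a functional assay on MDA-MB-231 cells (Homo sapiens) for antiproliferative activity, read by MTT assay, with a stated time of 48 h (a higher number here means a weaker inhibitor, a lower number a stronger inhibitor), compound 1 `CCS(=O)(=O)N1CCN(c2ncnc3sc(-c4ccc(N5CCN(C)CC5)cc4)cc23)CC1` gives 7330 nM and compound 2 `CN1CCN(c2ccc(-c3cc4c(N5CCN(C(=O)Nc6ccc(Cl)cc6)CC5)ncnc4s3)cc2)CC1` gives 5440 nM, so the two values lie within the scatter of each other. Compound 3 `CN1CCN(c2ccc(-c3cc4c(N5CCN(C(=O)Nc6ccccc6F)CC5)ncnc4s3)cc2)CC1` carries 2-fluorophenyl in place of 4-chlorophenyl on an amide-type nitrogen. Among the measured compounds shown here, the only measured step, a 1.3-fold lower number from compound 1 to compound 2 (0.13 log units; within the scatter), replaces ethylsulfonyl with (4-chlorophenyl)carbamoyl and does not test this swap, so no shift beyond the scatter is expected. The estimated step is a 1.1-fold lower number from compound 2 to compound 3 (0.04 log units; within the scatter). The estimate for compound 3 is 5000 nM, with an expected range of 2000 nM to 12000 nM.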

Compound 3, half-maximal inhibitory concentration: 10300 nM
Estimate against measurement, compound 3: 2.1-fold (0.31 log units) below; the range from low to high includes it.
By their numbers in this assay, from the lowest: compounds 2, 1 and 3 (each within the scatter of the next).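

Among the compounds shown here, the aryl group on the amide-type nitrogen is varied here for the first time: 2-fluorophenyl in place of 4-chlorophenyl gives a 1.9-fold higher number from compound 2 to compound 3 (0.28 log units; within the scatter) and so leaves the two compounds inseparable. Against ethylsulfonyl, (2-fluorophenyl)carbamoyl gives a 1.4-fold higher number from compound 1 to compound 3 (0.15 log units; within the scatter) in this assay and likewise does not stand apart. No measurement offered here bears on why these numbers fall as they do.
As far as these compounds go, whether an amine or a carboxylic acid on that phenyl ring, or a longer alkyl chain in its place, would move the number beyond the scatter remains open.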